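A few compounds are considered here, and "the series" means these few. Any claim that something is new, unique, unknown or untested is made for them only; others in the source may bear on it.

Measured compounds:
Compound 1 `c1ccc(-c2ccncn2)c(OCC2=NCCN2)c1`. In a functional assay for activation of Alpha-1B adrenergic receptor (Homo sapiens), read by calcium flux (on this read-out lower numbers stand for an effect already at smaller amounts and higher numbers for an effect only at larger amounts of compound), compound 1 gives < 100000 nM, which is a limit of the assay and not a number.
Compound 2 `c1c[nH]c(-c2ccccc2OCC2=NCCN2)c1`. In this assay compound 2 gives 1 nM.
Compound 3 `Cc1ccc(-c2ccccc2OCC2=NCCN2)s1`. In this assay compound 3 gives < 100000 nM, again a limit of the assay and not a number.

On these data alone, compound 1 therefore stands on a limit only; where it lies within that limit stays open. Compound 4 `Cc1csc(-c2ccccc2OCC2=NCCN2)n1` differs from compound 1 in a single place: 4-methyl-1,3-thiazol-2-yl in place of pyrimidin-4-yl on an aromatic carbon. Two measured steps start from compound 1. The step that the limit leaves unreadable from compound 1 to compound 2 could not be sized, and the step that the two limits leave unreadable from compound 1 to compound 3 could not be sized either, as both rest on (the limit of < 100000 nM in this assay, at which 2 of the 3 values shown sit). The remaining measured step that the limit leaves unreadable from compound 2 to compound 3 is unreadable for the same reason. Among the compounds with values here, no direction and no size of a step in this assay can thus be read from the measurements for the change from compound 1 to compound 4, and whether it goes beyond the usual scatter cannot be told in advance. For compound 4 a value of 1000 nM is estimated, with a range from 10 nM to 100000 nM. This estimate amounts to an expected step that the limit leaves unreadable from compound 1 to compound 4, with the chance that the assay again reports only a limit kept in view.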

Compound 4, half-maximal effective concentration: < 100000 nM
Compound 4: no number, only a limit; the forecaster's own chance of this, stated with the estimate: 50%; the middle value does not contradict the limit.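

In this assay compound 4 gives < 100000 nM as a limit of the assay and not a number. No new step to compound 4 from compound 1, compound 2 or compound 3 can be read, because each comparison rests on a limit: the limit of < 100000 nM in this assay, at which 3 of the 4 values shown sit.
The compounds shown leave open where compound 1, compound 3 and compound 4 truly lie in this assay and whether their groups differ in effect at all.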